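The source may report more compounds than this note shows. Statements on the series, on what has been measured and on what is new or still open speak of the compounds shown alone.

In an ADME assay on WI-38 cells (Homo sapiens) for cytotoxicity, read by sulforhodamine B assay, with a stated time of 24 h (on this read-out higher numbers stand for weaker inhibition and lower numbers for stronger inhibition), two compounds that share one core have been measured so far. Compound 1 (`N#CCC(=O)N/N=C1\C(=O)Nc2ccc(S(=O)(=O)N3CCOCC3)cc21`) gives 302000 nM, and compound 2 (`O=C1Nc2ccc(S(=O)(=O)N3CCOCC3)cc2/C1=N/c1ccc(Br)cc1`) gives 372000 nM. Among the compounds with values here, compound 2 therefore stands within the scatter of compound 1, its only neighbour on these numbers. Compound 3 (`O=C1Nc2ccc(S(=O)(=O)N3CCOCC3)cc2/C1=N/c1ccc(O)cc1`), still unmeasured, differs from compound 2 in one place, with hydroxy in place of bromo on an aromatic carbon, para to a large group: hydroxy in place of bromo on an aromatic carbon. No exchange of bromo for hydroxy has been measured on this core, so the evidence is indirect and thin. Within the data shown here, the only measured step that bears on it is a 1.2-fold higher number from compound 1 to compound 2 (0.09 log units; within the scatter), in which 4-bromophenyl replaces ((cyanomethyl)carbonyl)amino on a double-bonded nitrogen and the result stays within the scatter. On that single step, no change beyond the scatter is expected in this assay for the smaller exchange at hand. The estimated step is a 1.2-fold lower number from compound 2 to compound 3 (0.09 log units; within the scatter), with no firm direction expected. For compound 3 the estimated value is 300000 nM, with an expected range from 140000 nM to 560000 nM.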

Compound 3, half-maximal inhibitory concentration: 259000 nM
Estimate against measurement, compound 3: 1.2-fold (0.06 log units) above; the range from low to high includes it.
By their numbers in this assay, from the lowest: compounds 3, 1 and 2 (each within the scatter of the next).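

In this assay, the exchange of bromo for hydroxy on an aromatic carbon, para to a large group, now has a direct reading: a 1.4-fold lower number from compound 2 to compound 3 (0.16 log units; within the scatter). This place on the ring therefore tolerates the exchange without a change beyond the scatter, even though hydroxy brings a hydrogen-bond donor and a hydrogen-bond acceptor that bromo lacks. The 4-hydroxyphenyl group on the double-bonded nitrogen likewise stays level with the ((cyanomethyl)carbonyl)amino group, with a 1.2-fold lower number from compound 1 to compound 3 (0.07 log units; within the scatter), so a second aryl group now shows no separation from that group in this read-out, and nothing offered here accounts for this flat picture.

The compounds shown leave open whether an amine or a carboxylic acid on that same aromatic carbon would move the number beyond the scatter. They also leave open whether a longer chain on the double-bonded nitrogen, in place of the aryl groups, would separate from these three compounds, or whether the shared core simply sets the level seen so far.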